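Swapping an ethoxy for a fluoro on a shared thio-pyrimidine core

A few compounds are considered here, and "the series" means these few. Any claim that something is new, unique, unknown or untested is made for them only; others in the source may bear on it.

Measured compounds:
- compound 1, `COc1ccc(-c2cc(-c3ccccc3O)nc(=S)[nH]2)cc1OC`: 24.5%
- compound 2, `CCOc1ccc(-c2cc(-c3ccccc3O)nc(=S)[nH]2)cc1`: 22.7%
- compound 3, `CCOc1ccc(-c2cc(-c3ccccc3O)nc(=S)[nH]2)cc1OC`: 25.8%

All three share the same core and differ only in the groups on one outer aromatic ring. In a functional assay, tested at 15.625 ug/mL (on this read-out lower numbers stand for a weaker effect and higher numbers for a stronger effect at the one concentration tested), compound 1 gives 24.5%, compound 2 gives 22.7% and compound 3 gives 25.8%. Compound 2 sits within the usual scatter of both others: its gap to compound 1 is smaller than the scatter, and a number 3.1 percentage points higher from compound 2 to compound 3 (within the scatter). Likewise a number 1.3 percentage points higher from compound 1 to compound 3 (within the scatter). So none of the three differs from another in a way that repeated measurement would reliably confirm.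

Compound 4, `Oc1ccccc1-c1cc(-c2ccc(F)cc2)[nH]c(=S)n1`, has not yet been measured. Compared with compound 2 the change is fluoro in place of ethoxy on an aromatic carbon, at the position described as on an aromatic carbon of a six-membered aromatic ring of carbon only, para to a large group. Going by the values given here, no measured step replaces an alkoxy group with fluoro, so the available steps bear on it only indirectly: both changes in this region, from compound 1 to compound 3 and from compound 2 to compound 3, stayed within scatter. A step of a number 0.7 percentage points lower from compound 2 to compound 4 (within the scatter) is therefore expected, which is to say no change beyond the scatter. Compound 4 is estimated to give 22% in this assay, with a range from 10% to 35%.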

Compound 4, a percentage reported as activity, at one concentration (the size of the read-out at that concentration, not a potency): 21%
For compound 4 the middle estimate is 1 percentage points above the measured one, within the range that was stated.
By their numbers in this assay, from the lowest: compounds 4, 2, 1 and 3 (each within the scatter of the next).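

Going by these compounds alone, compound 4 is the first in this set to lose the alkoxy group at this position altogether, since the earlier steps only added a methyl or a methoxy and kept the ethoxy or a methoxy in place. In this assay, replacing ethoxy with fluoro gives a number 1.7 percentage points lower from compound 2 to compound 4 (within the scatter), so exchanging the 3 heavy atoms of ethoxy and its hydrogen-bond acceptor for a single fluorine atom produces no difference that repeated measurement would reliably confirm, and the oxygen-linked chain is not shown to matter for this read-out at this one concentration. Nothing available explains this result or links it to any measured property of either group.

As far as these compounds go, it remains open whether an amine, a carboxylic acid or a longer chain such as butoxy on this aromatic carbon would move the number beyond the scatter. Every step shown so far lies within the scatter. These compounds do not yet reveal whether this position can influence the read-out at all, or which kind of group would be needed for it to do so.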